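Sulfur-Linked Aryl Exchange on a Shared Core: Pyrimidinyl Analogue

A few compounds are considered here, and "the series" means these few. Any claim that something is new, unique, unknown or untested is made for them only; others in the source may bear on it.

Measured so far in a functional assay on PC-3 cells (Homo sapiens) for inhibition, read by MTT assay, with a stated time of 48 h; a higher number here means a weaker inhibitor, a lower number a stronger inhibitor:
compound 1 `C=C1CC[C@@H]2[C@](C)(CO)[C@H](O)CC[C@@]2(C)[C@@H]1CC(Sc1ccc(F)cc1)C1=CCOC1=O` gives 16000 nM;
compound 2 `C=C1CC[C@@H]2[C@](C)(CO)[C@H](O)CC[C@@]2(C)[C@@H]1CC(Sc1ccc(OC)cc1)C1=CCOC1=O` gives 15000 nM;
compound 3 `C=C1CC[C@@H]2[C@](C)(CO)[C@H](O)CC[C@@]2(C)[C@@H]1CC(Sc1ccccn1)C1=CCOC1=O` gives 18000 nM.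

Compound 1 stands second highest of the three numbers in this assay. Its nearest neighbour is compound 2, reached by a 1.1-fold lower number from compound 1 to compound 2 (0.03 log units; within the scatter), and its furthest is compound 3, reached by a 1.1-fold higher number from compound 1 to compound 3 (0.05 log units; within the scatter); both steps lie within the scatter, so the three measured compounds cannot be told apart on these numbers.

The unmeasured compound 4 `C=C1CC[C@@H]2[C@](C)(CO)[C@H](O)CC[C@@]2(C)[C@@H]1CC(Sc1ncccn1)C1=CCOC1=O` differs from compound 1 by pyrimidin-2-yl in place of 4-fluorophenyl on a sulfur. For the measured compounds named here, the steps that bear on this change are those that swap the aryl group on the sulfur: a 1.1-fold higher number from compound 1 to compound 3 (0.05 log units; within the scatter) and a 1.2-fold higher number from compound 2 to compound 3 (0.08 log units; within the scatter), each within the scatter. Replacing the 4-fluorophenyl by a six-membered aromatic ring carrying nitrogen has so far left this assay unchanged beyond the scatter, and the pyrimidin-2-yl is expected to behave the same way, with no step beyond the scatter in either direction.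

Compound 4 is therefore estimated at 18000 nM, with an expected range from 9000 nM to 36000 nM. The expected step is a 1.1-fold higher number from compound 1 to compound 4 (0.05 log units; within the scatter).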

Compound 4, half-maximal inhibitory concentration: 7000 nM
Compound 4: middle estimate off by 2.6-fold (0.41 log units), on the high side, outside the stated range (below it).
By their numbers in this assay, from the lowest: compound 4; then compounds 2, 1 and 3 (each within the scatter of the next).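

For the compounds shown here, on the sulfur, swapping one aryl group for another had so far changed nothing beyond the scatter, but in this assay pyrimidin-2-yl does, with a 2.3-fold lower number from compound 1 to compound 4 (0.36 log units; beyond the scatter) and a 2.1-fold lower number from compound 2 to compound 4 (0.33 log units; beyond the scatter) and a 2.6-fold lower number from compound 3 to compound 4 (0.41 log units; beyond the scatter) as modest steps that make compound 4 the strongest inhibitor of the four. This position therefore responds to the choice of ring, and a ring nitrogen alone does not account for the change: compound 3, with pyridin-2-yl, stays within the scatter of compound 1 and compound 2, so the step appears only with pyrimidin-2-yl, the ring with 2 hetero atoms. No evidence is available on why this ring gives the lower number.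

The compounds shown leave open whether the step belongs to the pyrimidin-2-yl group itself or would also appear with another ring carrying two nitrogens, such as pyrazin-2-yl or pyrimidin-4-yl. They also leave open whether the step would survive a substituent on the pyrimidine ring, such as an amine or a methyl group.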